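This account rests on a few compounds, and the source may have more. Where it says the series, first, only, none or still open, it means among the compounds named here.

Working notes on the series. In a functional assay on HT-29 cells (Homo sapiens) for inhibition, with a stated time of 72 h (on this read-out higher numbers stand for weaker inhibition and lower numbers for stronger inhibition), compound 3 `COc1ccc(S(=O)(=O)N2CCc3cccc(-c4ccc([N+](=O)[O-])cc4)c32)cc1` gives 51.8 nM, and compound 2 `COc1ccc(S(=O)(=O)N2CCc3cccc(-c4ccco4)c32)cc1` gives 62.5 nM, within the scatter of each other. Compound 1 `COc1ccc(S(=O)(=O)N2CCc3cccc(-c4ccc(F)nc4)c32)cc1` gives 109 nM, and only its gap to compound 3 lies beyond the scatter.

The open change leads to compound 4 `COc1ccc(S(=O)(=O)N2CCc3cccc(-c4ccc(F)c(F)c4)c32)cc1`, where 3,4-difluorophenyl stands in place of 4-nitrophenyl on an aromatic carbon: 3,4-difluorophenyl in place of 4-nitrophenyl on an aromatic carbon.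

Within the data shown here, three measured steps bear on it, all swaps of a group at this same place: a 1.7-fold lower number from compound 1 to compound 2 (0.24 log units; within the scatter), a 1.2-fold lower number from compound 2 to compound 3 (0.08 log units; within the scatter) and a 2.1-fold lower number from compound 1 to compound 3 (0.32 log units; beyond the scatter). These steps are small, so no step beyond the scatter is expected in this assay. Among the measured compounds shown here, compound 1, at 109 nM, is the only measured compound whose group carries fluorine, which gives a slight lean towards a higher number. The estimated step is a 1.4-fold higher number from compound 3 to compound 4 (0.16 log units; within the scatter). Compound 4 is expected at about 75 nM, with an estimated range of 32 nM to 170 nM.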

Compound 4, half-maximal inhibitory concentration: 57 nM
Beside the measured number, compound 4's estimate is 1.3-fold (0.12 log units) above it; low and high end bracket the measured number.
By their numbers in this assay, from the lowest: compounds 3, 4, 2 and 1 (each within the scatter of the next, the first and the last beyond it).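

In this assay, 3,4-difluorophenyl in place of 4-nitrophenyl gives a 1.1-fold higher number from compound 3 to compound 4 (0.04 log units; within the scatter) and in place of furan-2-yl gives a 1.1-fold lower number from compound 2 to compound 4 (0.04 log units; within the scatter) so this aromatic carbon accepts a group with 0 hydrogen-bond acceptors as readily as 4-nitrophenyl, which has 2. The step against 6-fluoropyridin-3-yl is a 1.9-fold lower number from compound 1 to compound 4 (0.28 log units; within the scatter) and compound 4 also carries fluorine, so the earlier lean linking fluorine to a higher number finds no support here. No measured evidence accounts for how closely these groups read.

All four groups shown are aromatic rings attached directly at this carbon. As far as these compounds go, what an amine, a carboxylic acid or a saturated ring such as morpholine would do at this place remains open.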